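Swapping Fluoro for Bromo on an Aromatic Ring

The compounds below may be only part of what the source reports. "The series", "measured", "known", "first", "only" and "open" are said of these compounds alone.

Measured compounds:
compound 1, `CNC(=O)c1cc(Oc2ccc(/C=C/C(=O)c3ccc(C)cc3)cc2)ccn1`: "not determined" (no result reported)
compound 2, `CNC(=O)c1cc(Oc2ccc(C(=O)/C=C/c3cccc(Br)c3)cc2)ccn1`: 3400 nM
compound 3, `CNC(=O)c1cc(Oc2ccc(C(=O)/C=C/c3ccc(F)cc3)cc2)ccn1`: 6140 nM

Three compounds share one core and differ only in the halogen-bearing aromatic ring at the end of the double-bonded chain. In a functional assay on PC-3 cells (Homo sapiens) for cytotoxicity, read by MTT assay, with a stated time of 72 h (a higher number here means a weaker inhibitor, a lower number a stronger inhibitor), compound 2 gives 3400 nM and compound 3 gives 6140 nM, while compound 1 has no result reported. Among the compounds with values here, compound 3 therefore holds the highest of the two available numbers, but its only neighbour, compound 2, lies within the scatter of it, so no order between them can be claimed.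

Compound 4, `CNC(=O)c1cc(Oc2ccc(C(=O)/C=C/c3ccc(Br)cc3)cc2)ccn1`, is the next step. Its change from compound 3 is bromo in place of fluoro on an aromatic carbon. Within the data shown here, the one measured step that bears on it is a 1.8-fold higher number from compound 2 to compound 3 (0.26 log units; within the scatter), which compares a bromo and a fluoro ring as well, although on different ring positions; it stayed within the scatter. On that basis no step beyond the scatter is expected for a 1.4-fold lower number from compound 3 to compound 4 (0.13 log units; within the scatter), with the number perhaps drifting a little lower. Compound 4 is estimated at 4500 nM, with a range from 2000 nM to 10000 nM.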

Compound 4, half-maximal inhibitory concentration: 18500 nM
Beside the measured number, compound 4's estimate is 4.1-fold (0.61 log units) below it; the measured number lies above the stated range.
By their numbers in this assay, from the lowest: compounds 2 and 3 (each within the scatter of the next); then compound 4.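

In this assay the swap of fluoro for bromo, on an aromatic carbon para to a large group, is a change that reaches beyond the scatter (a 3.0-fold higher number from compound 3 to compound 4 (0.48 log units; beyond the scatter)). Keeping bromo on the ring and going from 3-bromophenyl to 4-bromophenyl also matters (a 5.4-fold higher number from compound 2 to compound 4 (0.74 log units; beyond the scatter)), so where the bromo stands affects the number as well as which halogen is present. The earlier step (a 1.8-fold higher number from compound 2 to compound 3 (0.26 log units; within the scatter)) changed the halogen and its ring position together and stayed within the scatter, which hid both of these effects, and no measurement shown here explains either of them.

The compounds shown leave open whether 3-fluorophenyl would complete the comparison, showing if fluoro and bromo also differ at the other ring position. They also leave open whether 4-chlorophenyl would fall with the 4-fluorophenyl or the 4-bromophenyl compound, and how a larger change at that ring carbon, such as an amine or a carboxylic acid, would compare with these halogens.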